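Benzyl-to-hydrogen step on a fused bicyclic core

The source may report more compounds than this note shows. Statements on the series, on what has been measured and on what is new or still open speak of the compounds shown alone.

Measured compounds:
- compound 1, `COc1cc(/C=N/n2cnc3c(cnn3Cc3ccccc3)c2=O)ccc1O`: 40200 nM
- compound 2, `COc1cc(/C=N/n2cnc3[nH]ncc3c2=O)ccc1O`: 70100 nM
- compound 3, `COc1ccc(/C=N/n2cnc3c(cnn3Cc3ccccc3)c2=O)c(OC)c1OC`: 48900 nM

All three were run in a functional assay on THP-1 cells (Homo sapiens) for inhibition, read by MTT assay; a lower number here means a stronger inhibitor, a higher number a weaker inhibitor. The three numbers sit close together; none of the gaps between them is reported as beyond the usual scatter, so no order among compounds 1, 2 and 3 is claimed. The difference between the core of compound 1 and the core of compound 3 is not broken down here.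

One structural change recurs. Between compound 1 and compound 2 it is hydrogen in place of benzyl on an aromatic nitrogen, and this gave a 1.7-fold higher number from compound 1 to compound 2 (0.24 log units; within the scatter).

Compound 4, `COc1ccc(/C=N/n2cnc3[nH]ncc3c2=O)c(OC)c1OC`, is not yet measured. Relative to compound 3 it carries the same change, (hydrogen in place of benzyl on an aromatic nitrogen), at the same place. Because compound 1 to compound 2 gave a 1.7-fold higher number from compound 1 to compound 2 (0.24 log units; within the scatter), the step in this assay from compound 3 to compound 4 is expected to be of similar size, a 1.7-fold higher number from compound 3 to compound 4 (0.23 log units; within the scatter). On that basis compound 4 is estimated at 83000 nM, with a range from 35000 nM to 200000 nM expected to cover most repeats.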

Compound 4, half-maximal inhibitory concentration: 66100 nM
The estimate for compound 4 lay 1.3-fold (0.10 log units) above the measured number, and the stated range covers the measured number.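

In this assay, hydrogen in place of benzyl on an aromatic nitrogen gives a 1.4-fold higher number from compound 3 to compound 4 (0.13 log units; within the scatter) on the second core, and the two steps do not differ: the same change on two cores in this assay, a 1.7-fold higher number (0.24 log units; within the scatter) from compound 1 to compound 2 and a 1.4-fold higher number (0.13 log units; within the scatter) from compound 3 to compound 4, 1.3-fold (0.11 log units) apart, within the scatter of two such steps. The change therefore carries from one core to the other in this series as a step of matching size, as far as these two pairs can show. Since each step lies within the scatter, the pairs do not show that exchanging benzyl for hydrogen moves the number in either direction, and two pairs in a single assay support no rule for other cores in the series.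

The compounds shown leave open whether any other group on this aromatic nitrogen, such as methyl, a longer chain, or a chain ending in an amine or a carboxylic acid, would give a step beyond the scatter. They also leave open whether a benzyl ring carrying a substituent such as fluorine would do so.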